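The compounds below may be only part of what the source reports. "The series", "measured", "known", "first", "only" and "open" are said of these compounds alone.

Values in a functional assay on K562 cells (Homo sapiens) for inhibition, read by sulforhodamine B assay, with a stated time of 48 h; on this read-out higher numbers stand for weaker inhibition of growth and lower numbers for stronger inhibition of growth:
- compound 1 `S=C(N/N=C/c1cccs1)Nc1ccc(Cl)cc1`: 2000 nM
- compound 2 `Cc1ccc(NC(=S)N/N=C/c2cccs2)cc1`: < 900 nM (a limit of the assay)
- compound 3 `COc1ccc(NC(=S)N/N=C/c2cccs2)cc1`: 1700 nM

Compound 3 stands level with compound 1 within the scatter, with a 1.2-fold lower number from compound 1 to compound 3 (0.07 log units; within the scatter). The only other entry in the series is a limit, so compound 3 has just one true number to be compared with.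

Compound 4 `CCc1ccc(NC(=S)N/N=C/c2cccs2)cc1` changes one group of compound 3: ethyl in place of methoxy on an aromatic carbon. This is ethyl in place of methoxy on an aromatic carbon, para to a large group.

Among the measured compounds shown here, no ethyl compound has been measured, so two steps at this place serve as a guide. The first is an at least 1.8-fold higher number from compound 2 to compound 3 (0.27 log units; that floor lies within the scatter), whose floor lies within the scatter. The second is an at least 2.2-fold lower number from compound 1 to compound 2 (0.34 log units; beyond the scatter), which lies beyond the scatter. Methyl in compound 2 is the only measured group made of carbon alone at this place, so ethyl is expected to read closer to methyl than to methoxy. In this assay a modest move to a lower number is therefore expected, although a result within the scatter of compound 3 remains possible.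

The expected change is a 1.7-fold lower number from compound 3 to compound 4 (0.23 log units; within the scatter).
For compound 4 the estimated value is 1000 nM.
The estimated range for compound 4 runs from 450 nM to 2200 nM.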

Compound 4, concentration for 50% growth inhibition: 1600 nM
The estimate for compound 4 lay 1.6-fold (0.20 log units) below the measured number; measured number inside the range.
By their numbers in this assay, from the lowest: compounds 4, 3 and 1 (each within the scatter of the next). At a limit, below all of these: compound 2.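

In this assay, ethyl in place of methoxy on an aromatic carbon, para to a large group, gives a 1.1-fold lower number from compound 3 to compound 4 (0.03 log units; within the scatter), so exchanging methoxy with its hydrogen-bond acceptor for ethyl with none produces no readable change at this position. Against chloro the picture is the same, with a 1.3-fold lower number from compound 1 to compound 4 (0.10 log units; within the scatter), which places the chloro, methoxy and ethyl compounds on one level and shows that a group of carbon alone at this place does not by itself go with the low reading of compound 2, the only compound that departs from this level. The step from methyl to ethyl is only a floor, an at least 1.7-fold higher number from compound 2 to compound 4 (0.24 log units; that floor lies within the scatter), and it cannot separate the two groups because the reading for compound 2 is a limit: the limit of < 900 nM in this assay, at which 1 of the 4 values shown sits.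

From the compounds shown here alone, the true number for compound 2 stays open, and with it whether methyl differs from ethyl at all. Also open, going by these compounds, is whether a longer chain such as propyl, a hydroxyl or an amine at this place would read away from the level of compounds 1, 3 and 4.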